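The compounds below may be only part of what the source reports. "The series", "measured", "known", "first", "only" and "open" are said of these compounds alone.

In a functional assay on HepG2 cells (Homo sapiens) for cytotoxicity, read by WST assay, with a stated time of 24 h (a higher number here means that more compound is tolerated, a lower number that less compound is tolerated), compound 1 `CCCC=Cc1cc(-c2ccc3cc(C(=O)O)ccc3c2)ccc1O` gives 5.38 ug/mL and stands level with the other two measured compounds, as all three values lie within the scatter of one another. Compound 2 `CC(C)(C)c1cc(-c2ccc3cc(CO)ccc3c2)ccc1O` gives 7.5 ug/mL and compound 3 `CCCCCCCC=Cc1cc(-c2ccc3cc(CO)ccc3c2)ccc1O` gives 5.51 ug/mL in the same read-out.

The next compound is compound 4 `CCCCCc1cc(-c2ccc3cc(C(=O)O)ccc3c2)ccc1O` with pentyl in place of pent-1-en-1-yl on an aromatic carbon, ortho to a hydroxy group pentyl in place of pent-1-en-1-yl on an aromatic carbon and otherwise the same structure as compound 1.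

Among the compounds with values here, only one measured step bears on this change: a 1.4-fold lower number from compound 2 to compound 3 (0.13 log units; within the scatter). It also swaps the group on an aromatic carbon, though in a pair that differs from compound 1 elsewhere, and it stays within the scatter. Within the data shown here, no measured pair isolates the loss of the chain double bond, so this evidence is indirect.

The estimated step of a 1.0-fold higher number from compound 1 to compound 4 (0.01 log units; within the scatter) is expected to stay within the scatter, with no direction favoured. Compound 4 is expected at 5.5 ug/mL with an estimated range from 3.2 ug/mL to 9 ug/mL.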

Compound 4, concentration lethal to 50% of the cells: 3.26 ug/mL
The estimate for compound 4 lay 1.7-fold (0.23 log units) above the measured number, and the stated range covers the measured number.
By their numbers in this assay, from the lowest: compounds 4, 1, 3 and 2 (each within the scatter of the next, the first and the last beyond it).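

In this assay, within the data shown here, a 1.7-fold lower number from compound 1 to compound 4 (0.22 log units; within the scatter) gives the first reading of the chain double bond alone, with the 5 carbons of the chain kept on the same aromatic carbon, ortho to a hydroxy group. Removing this double bond therefore leaves the number within the scatter for this pair, as does the different swap at this position in a 1.4-fold lower number from compound 2 to compound 3 (0.13 log units; within the scatter). No measurement bears on the reason for the size of the step.

The compounds shown leave open whether a markedly longer saturated chain, a cyclohexyl group or an amine at this position would move the number beyond the scatter. They also leave open whether the same loss of the double bond stays within the scatter when the carboxylic acid of compound 4 is replaced, for example by an amide.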